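Stereochemistry in a diamide series: compound 2 to compound 3

A few compounds are considered here, and "the series" means these few. Any claim that something is new, unique, unknown or untested is made for them only; others in the source may bear on it.

Measured: compound 1 `O=C(NC1CCCC(NC(=O)c2ccccn2)C1)c1cccc(Cl)c1` gives 314 nM in a functional assay on HEK293 cells for antagonist activity at metabotropic glutamate receptor 5 (Homo sapiens), read by FLIPR and calcium flux; on this read-out lower numbers stand for stronger inhibition and higher numbers for weaker inhibition; compound 2 `O=C(N[C@@H]1CCC[C@@H](NC(=O)c2ccccn2)C1)c1cccc(Cl)c1` gives 62 nM in this assay.

Compound 2 stands with the lowest number of the two. Among the compounds with values here, the only measured step, a 5.1-fold lower number from compound 1 to compound 2 (0.70 log units; beyond the scatter), rests on (the fact that one of compounds 1 and 2 is drawn with a defined configuration and the other without, at the place where they differ). Compound 3 `O=C(N[C@@H]1CCC[C@H](NC(=O)c2ccccn2)C1)c1cccc(Cl)c1` differs from compound 2 thus: the two compounds have the same atoms and bonds and differ only in configuration as drawn: 1 of 2 stereo elements differ; a stereocentre at a saturated ring carbon is drawn R in compound 2 and S in compound 3. Compound 2 being the resolved isomer and already stronger than the undefined compound 1 suggests the other isomers are weaker; a modest step upward is therefore expected, a 13-fold higher number from compound 2 to compound 3 (1.11 log units; beyond the scatter). Compound 3 is estimated at 800 nM, range 200 nM to 4000 nM.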

Compound 3, half-maximal inhibitory concentration: 1510 nM
Estimate against measurement, compound 3: 1.9-fold (0.28 log units) below, and the stated range covers the measured number.
By their numbers in this assay, from the lowest: compound 2; then compound 1; then compound 3.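

Changing one stereocentre at a saturated ring carbon, with atoms and bonds unchanged, gives a 24-fold higher number from compound 2 to compound 3 (1.39 log units; beyond the scatter) in this assay, so configuration alone separates these two defined isomers: the fact that compounds 2 and 3 differ only in the configuration as drawn

Compound 3 also lies on the weaker side of the undefined material, with a 4.8-fold higher number from compound 1 to compound 3 (0.68 log units; beyond the scatter), so a defined configuration does not by itself give a lower number: the fact that one of compounds 1 and 3 is drawn with a defined configuration and the other without, at the place where they differ

Open, going by these compounds, are the remaining configurations at these two stereocentres, and whether the same preference holds with an amine or a carboxylic acid in place of the chlorine.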